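A few compounds are considered here, and "the series" means these few. Any claim that something is new, unique, unknown or untested is made for them only; others in the source may bear on it.

Compound 1 `CCCCCc1cc(C)c(C(=O)N=C(N)N)cc1S(C)(=O)=O`: 27 nM
Compound 2 `Cc1cc(-c2ccco2)c(S(C)(=O)=O)cc1C(=O)N=C(N)N`: 16 nM
Compound 3 `Cc1cc(Sc2ccncc2)c(S(C)(=O)=O)cc1C(=O)N=C(N)N`: 13 nM

In a functional assay for inhibition of sodium/hydrogen exchanger (Oryctolagus cuniculus) (a higher number here means a weaker inhibitor, a lower number a stronger inhibitor), compound 3 gives 13 nM, the lowest of the three numbers. Its nearest neighbour is compound 2, separated by a 1.2-fold lower number from compound 2 to compound 3 (0.09 log units; within the scatter), so the two cannot be ranked against each other. Compound 1 sits further off, by a 2.1-fold lower number from compound 1 to compound 3 (0.32 log units; beyond the scatter), a modest gap. Compound 4 `Cc1cc(N2CCCC(O)C2)c(S(C)(=O)=O)cc1C(=O)N=C(N)N` differs from compound 3 in one place: 3-hydroxypiperidin-1-yl in place of (pyridin-4-yl)sulfanyl on an aromatic carbon. Going by the values given here, none of the measured steps exchanges the group on this aromatic carbon for one with a non-aromatic ring or a hydrogen-bond donor, so no step bears directly on the change. What the steps do show is that varied groups at this carbon move this assay only a little: a 1.7-fold lower number from compound 1 to compound 2 (0.23 log units; within the scatter) stays within the scatter, and a 2.1-fold lower number from compound 1 to compound 3 (0.32 log units; beyond the scatter) is modest. Compound 4 is therefore expected to remain in the same region, with at most a somewhat higher number, an estimated 2.3-fold higher number from compound 3 to compound 4 (0.36 log units; beyond the scatter). The expected value for compound 4 is 30 nM, with an estimated range from 8 nM to 110 nM.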

Compound 4, half-maximal inhibitory concentration: 30 nM
Compound 4: the middle estimate sits on the measured number at the digits printed; the range from low to high includes it.
By their numbers in this assay, from the lowest: compounds 3, 2, 1 and 4 (each within the scatter of the next, the first and the last beyond it).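

On the aromatic carbon ortho to the methylsulfonyl group, 3-hydroxypiperidin-1-yl shows that a non-aromatic ring with a hydroxyl group also fits the range set by the earlier groups in this assay: a 1.1-fold higher number from compound 1 to compound 4 (0.05 log units; within the scatter) and a 1.9-fold higher number from compound 2 to compound 4 (0.27 log units; within the scatter) both stay within the scatter. Only the exchange for (pyridin-4-yl)sulfanyl registers, with a 2.3-fold higher number from compound 3 to compound 4 (0.36 log units; beyond the scatter) as a modest step, so losing the aromatic ring and gaining a hydrogen-bond donor together do not move the number far. Nothing available explains why this carbon accepts such different groups.

The compounds shown leave open whether plain piperidin-1-yl, without the hydroxyl group, would give a similar number in this assay. They also leave open how a carboxylic acid or a primary amine at this carbon would behave.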